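This account rests on a few compounds, and the source may have more. Where it says the series, first, only, none or still open, it means among the compounds named here.

In an ADME assay (liver, Mus musculus) for metabolic stability, using microsomes (a higher number here means that the compound lasts longer, a lower number that the compound disappears faster), compound 1 (`CCCc1nc2ccccn2c1C(=O)NCc1ccc(-c2ccccc2)cc1`) gives 0.145 h. Compound 2 (`CCc1nc2cc(Cl)ccn2c1C(=O)NCc1ccc(-c2ccc(Cl)cc2)cc1`) stands at > 1 h, which is a limit of the assay and not a number. Compound 3 (`CCc1nc2cc(Cl)ccn2c1C(=O)NCc1ccc(-c2ccc[nH]2)cc1`) has 1H-pyrrol-2-yl in place of 4-chlorophenyl on an aromatic carbon, para to a large group: 1H-pyrrol-2-yl in place of 4-chlorophenyl on an aromatic carbon. Among the compounds with values here, no measured pair isolates this change. A clear drop in this assay is expected, with compound 1 at 0.145 h showing how short the half-life can be in this series. The expected change is an at least 3.3-fold lower number from compound 2 to compound 3 (0.52 log units; beyond the scatter). For compound 3, the estimated half-life is 0.3 h, with an expected range of 0.1 h to 0.9 h.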

Compound 3, half-life: 0.18 h
Estimate against measurement, compound 3: 1.7-fold (0.22 log units) above; low and high end bracket the measured number.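

Within the data shown here, compounds 2 and 3 are the one pair here that differs in one place, and they show that this position, on an aromatic carbon para to a large group, strongly affects the half-life in this assay: 1H-pyrrol-2-yl in place of 4-chlorophenyl gives an at least 5.5-fold lower number from compound 2 to compound 3 (0.74 log units; beyond the scatter). Compound 2 stands at a limit of the assay and not at a number, so the full size of the step stays unknown: the limit of > 1 h in this assay, at which 1 of the 3 values shown sits.

From the compounds shown here alone, whether the fall follows the loss of the six-membered ring, of the chlorine, or the entry of the ring hydrogen-bond donor stays open. A 1-methylpyrrol-2-yl group, with a methyl on the ring nitrogen, would help to separate these on the same core.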